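Compound 2 to compound 4: bromo for methyl

The source may report more compounds than this note shows. Statements on the series, on what has been measured and on what is new or still open speak of the compounds shown alone.

Measured so far in an ADME assay on Vero cells (Chlorocebus sabaeus) for cytotoxicity, read by resazurin assay, with a stated time of 72 h; on this read-out higher numbers stand for weaker inhibition and lower numbers for stronger inhibition
compound 1 `Cc1ccc(C(=O)CCN2CCN(c3ccc(F)cc3)CC2)cc1` gives 55400 nM
compound 2 `Cc1ccc(C(=O)CCN2CCN(c3ccc(C(F)(F)F)cc3)CC2)cc1` gives 140000 nM
compound 3 `Cc1ccc(C(=O)CCN2CCN(c3ccc([N+](=O)[O-])cc3)CC2)cc1` gives 235000 nM

Compound 2 stands with the higher pair of numbers: the gap inside that pair (a 1.7-fold higher number from compound 2 to compound 3 (0.22 log units; within the scatter)) lies within the scatter, while the step out of it (a 2.5-fold higher number from compound 1 to compound 2 (0.40 log units; beyond the scatter)) is modest. Compound 4 `O=C(CCN1CCN(c2ccc(C(F)(F)F)cc2)CC1)c1ccc(Br)cc1` carries bromo in place of methyl on an aromatic carbon, para to a large group (bromo in place of methyl on an aromatic carbon). Among the compounds with values here, no measured step touches that place. The measured steps exchange fluoro, trifluoromethyl and nitro elsewhere, the largest (a 4.2-fold higher number from compound 1 to compound 3 (0.63 log units; beyond the scatter)) staying modest. They suggest no direction, so no step beyond the scatter is expected in this assay here. The expected step is small (a 1.1-fold lower number from compound 2 to compound 4 (0.03 log units; within the scatter)). Compound 4 is estimated at 130000 nM (range 60000 nM to 280000 nM).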

Compound 4, half-maximal inhibitory concentration: 78800 nM
Estimate against measurement, compound 4: 1.6-fold (0.22 log units) above, within the range that was stated.
By their numbers in this assay, from the lowest: compounds 1, 4, 2 and 3 (each within the scatter of the next, the first and the last beyond it).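

In this assay, within the data shown here, the exchange of 4-methylphenyl for 4-bromophenyl, the first change at this place, gives a 1.8-fold lower number from compound 2 to compound 4 (0.25 log units; within the scatter) and so stays small against the steps among fluoro, trifluoromethyl and nitro. This place, on an aromatic carbon para to a large group, therefore shows no step beyond the scatter for this one exchange, with trifluoromethyl kept in the shared core. Nothing available bears on why this result arises.

Open, on these data alone, is whether bromo in place of methyl reads the same with fluoro or nitro in place of trifluoromethyl. Also open, as far as these compounds go, is whether an amine or a carboxylic acid at this place gives a step beyond the scatter.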